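Cytotoxicity limits in the chlorinated nitrobenzamide series

The source may hold more compounds than are shown below. What is called first, only, known or untested is meant among the compounds shown, and "the series" means these compounds.

Compound 1 `O=C(Nc1ccc(-c2nc3ccccc3s2)cc1)c1cc([N+](=O)[O-])ccc1Cl` - > 27000 nM - a limit
Compound 2 `O=C(Nc1ccc(-c2ccccc2)cc1)c1cc([N+](=O)[O-])ccc1Cl` - > 27000 nM - a limit
Compound 3 `O=C(Nc1ccc(Cl)c(C(F)(F)F)c1)c1cc([N+](=O)[O-])ccc1Cl` - > 27000 nM - a limit

In an ADME assay on BJ cells (Homo sapiens) for cytotoxicity, with a stated time of 72 h (on this read-out lower numbers stand for an effect already at smaller amounts and higher numbers for an effect only at larger amounts of compound), compound 3 gives > 27000 nM, which is a limit and not a number. It shares that position with the other two compounds: the limit of > 27000 nM in this assay, at which 3 of the 3 values shown sit.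

Compound 4 `O=C(Nc1ccc(Cl)cc1)c1cc([N+](=O)[O-])ccc1Cl` differs from compound 3 by one change, hydrogen in place of trifluoromethyl on an aromatic carbon, ortho to a chloro group and meta to a large group: hydrogen in place of trifluoromethyl on an aromatic carbon.

Within the data shown here, the only measured step is a step that the two limits leave unreadable from compound 1 to compound 2. It is a different change, and it gives no size to carry over. Among the measured compounds shown here, no measured step involves trifluoromethyl.

With compound 3 and the rest of the series at the limit in this assay, no step beyond the scatter is expected, and no direction can be given. The expected step is a step that the limit leaves unreadable from compound 3 to compound 4, and a reading at the same limit is the likeliest outcome. The estimate for compound 4 is 30000 nM, with an expected range of 14000 nM to 60000 nM.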

Compound 4, half-maximal effective concentration: > 27000 nM
Compound 4 was reported as a limit (the forecaster's own chance of this, stated with the estimate: 85%); the middle value does not contradict the limit.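

No step from compound 1, compound 2 or compound 3 to compound 4 can be read, as all four values are limits: the limit of > 27000 nM in this assay, at which 4 of the 4 values shown sit.

The compounds shown leave open at what concentration any of them would reach a half-maximal effect in this assay, and whether any of these changes shifts it.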